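A few compounds are considered here, and "the series" means these few. Any claim that something is new, unique, unknown or untested is made for them only; others in the source may bear on it.

Working notes on the tocopherol-type carbamates.

Compound 1 `CC(C)=CCC/C(C)=C/CC/C(C)=C/CC[C@]1(C)CCc2c(C)c(OC(=O)Nc3ccccc3)c(C)c(C)c2O1` carries a phenylcarbamate on the fully methylated core. In a functional assay on MDA-MB-231 cells (Homo sapiens) for antiproliferative activity, read by MTT assay, with a stated time of 96 h (on this read-out lower numbers stand for stronger inhibition and higher numbers for weaker inhibition), compound 1 gives > 10000 nM, which is a limit of the assay and not a number. Compound 2 `CC(C)=CCC/C(C)=C/CC/C(C)=C/CC[C@]1(C)CCc2c(C)c(OC(=O)NS(=O)(=O)c3ccccc3)c(C)c(C)c2O1` bears the phenylsulfonylcarbamate on the same core. In this assay compound 2 gives > 10000 nM, again a limit. The change phenyl in place of phenylsulfonyl on an amide-type nitrogen therefore yields a step that the two limits leave unreadable from compound 2 to compound 1, because both readings sit at the limit of > 10000 nM in this assay, at which 3 of the 3 values shown sit.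

Compound 3 `CC(C)=CCC/C(C)=C/CC/C(C)=C/CC[C@]1(C)CCc2cc(OC(=O)NS(=O)(=O)c3ccccc3)cc(C)c2O1` carries the phenylsulfonylcarbamate on a less methylated core; the difference between the two cores is not broken down here. In this assay compound 3 gives > 10000 nM, once more a limit.

Compound 4 `CC(C)=CCC/C(C)=C/CC/C(C)=C/CC[C@]1(C)CCc2cc(OC(=O)Nc3ccccc3)cc(C)c2O1` is not yet measured. It differs from compound 3 by phenyl in place of phenylsulfonyl on an amide-type nitrogen, the same change as from compound 2 to compound 1. Beside the earlier unreadable step, the step that the limit leaves unreadable from compound 3 to compound 4 is expected to stay unreadable as well, because compound 3 already rests at the limit of > 10000 nM in this assay, at which 3 of the 3 values shown sit. Compound 4 is estimated at 15000 nM, most probably reported as a limit only.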

Compound 4, half-maximal inhibitory concentration: > 10000 nM
Compound 4 was reported as a limit; the forecaster's own chance of this, stated with the estimate: 85%; the middle value is on the limit's open side.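

In this assay compound 4 gives > 10000 nM, again a limit of the assay and not a number. No size can be read for the change from compound 3 to compound 4, because both compounds rest at the same limit: the limit of > 10000 nM in this assay, at which 4 of the 4 values shown sit.

The compounds shown leave open how phenyl and phenylsulfonyl on the amide-type nitrogen, or the two cores, compare in this assay.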